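This account rests on a few compounds, and the source may have more. Where it says the series, first, only, none or still open, it means among the compounds named here.

Working notes on the series. The three measured compounds share a fused core: compound 1 `CCCC(C)n1c(CC)nc2c(-c3ccc(OC)cc3C)ccnc21`, compound 2 `CCc1nc2c(-c3ccc(Cl)cc3Cl)ccnc2n1C(CCOC)C1CC1` and compound 3 `CCc1nc2c(-c3ccc(C(F)(F)F)cc3Cl)ccnc2n1C(CC)CCOC`. In an assay for binding affinity to Corticotropin releasing factor receptor (Rattus norvegicus) (a lower number here means a stronger inhibitor, a higher number a weaker inhibitor), compound 1 gives 0.8 nM. In this assay compound 2 gives 1.5 nM, the highest number of the three; its gap to compound 1 lies within the scatter, while its gap to compound 3 lies beyond it. In this assay compound 3 gives 0.7 nM.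

Compound 4 `CCc1nc2c(-c3ccc(Cl)cc3Cl)ccnc2n1C(C)C1CCC1` remains unmeasured. It differs from compound 2 in one place: 1-cyclobutylethyl in place of 1-cyclopropyl-3-methoxypropyl on an aromatic nitrogen. For the measured compounds named here, no measured pair isolates this change. The expected step of a 2.0-fold higher number from compound 2 to compound 4 (0.30 log units; within the scatter) is small, toward a slightly higher number, and may not exceed the scatter. For compound 4 the estimate in this assay is 3 nM, in the range 1 nM to 9 nM.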

Compound 4, inhibition constant: 1 nM
The estimate for compound 4 lay 3.0-fold (0.48 log units) above the measured number; low and high end bracket the measured number.
By their numbers in this assay, from the lowest: compounds 3, 1, 4 and 2 (each within the scatter of the next, the first and the last beyond it).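

In this assay, this pair isolates the group on the aromatic nitrogen, and the swap gives a 1.5-fold lower number from compound 2 to compound 4 (0.18 log units; within the scatter), so 1-cyclobutylethyl and 1-cyclopropyl-3-methoxypropyl cannot be told apart here. In this pair, neither the oxygen of the leaving chain nor the three-membered ring is needed for a low number. Nothing available explains this result.

On these data alone, whether an amine or a carboxylic acid carried on this nitrogen substituent would keep the number this low remains open. As far as these compounds go, it is also open whether the same swap would behave alike with the aryl groups of compound 1 and compound 3.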